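Aryl ether versus dichlorophenyl thioether on two cores

This account rests on a few compounds, and the source may have more. Where it says the series, first, only, none or still open, it means among the compounds named here.

Measured so far:
Compound 1 `c1ccc(Oc2ncnc3c2ncn3C2COc3ccccc3CO2)cc1`: in a functional assay on MCF7 cells (Homo sapiens) for antiproliferative activity, read by sulforhodamine B assay, with a stated time of 3 days (a higher number here means a weaker inhibitor, a lower number a stronger inhibitor), compound 1 gives 24700 nM.
Compound 2 `Clc1ccc(Sc2ncnc3c2ncn3C2COc3ccccc3CO2)c(Cl)c1`: compound 2 gives 12000 nM.
Compound 3 `c1ccc(Oc2ncnc3ncn(C4COc5ccccc5CO4)c23)cc1`: compound 3 gives 21100 nM.

One counted step exists, a 2.1-fold lower number from compound 1 to compound 2 (0.31 log units; beyond the scatter), and the change behind it is (2,4-dichlorophenyl)sulfanyl in place of phenoxy on an aromatic carbon. Compound 3 shares its atoms with compound 1, joined differently; the difference between the two cores is not broken down here. The values of compound 3 and compound 1 lie within the scatter of each other, as do those of compound 3 and compound 2.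

Compound 4 `Clc1ccc(Sc2ncnc3ncn(C4COc5ccccc5CO4)c23)c(Cl)c1` is not yet measured. It differs from compound 3 by (2,4-dichlorophenyl)sulfanyl in place of phenoxy on an aromatic carbon. The place described for this change matches that of the change from compound 1 to compound 2 word for word, so it is the same change on the other core. Within the data shown here, a step of similar size is expected, a 2.0-fold lower number from compound 3 to compound 4 (0.30 log units; within the scatter), because a 2.1-fold lower number from compound 1 to compound 2 (0.31 log units; beyond the scatter) is the only precedent available. For compound 4 the expected value is 10500 nM. The likely range for compound 4 is estimated as 5000 nM to 22000 nM.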

Compound 4, half-maximal inhibitory concentration: 8400 nM
Estimate against measurement, compound 4: 1.3-fold (0.10 log units) above; the measured number falls inside the stated range.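

In this assay, (2,4-dichlorophenyl)sulfanyl in place of phenoxy gives a 2.5-fold lower number from compound 3 to compound 4 (0.40 log units; beyond the scatter) and the earlier step is matched, so in this series the change carries from one core to the other with its direction and size kept: the same change on two cores in this assay, a 2.1-fold lower number (0.31 log units; beyond the scatter) from compound 1 to compound 2 and a 2.5-fold lower number (0.40 log units; beyond the scatter) from compound 3 to compound 4, 1.2-fold (0.09 log units) apart, within the scatter of two such steps. This rests on one pair per core and on a single change, so it shows nothing about whether other groups at this aromatic carbon would carry across in the same way. The change also swaps the oxygen for sulfur and adds the chlorines together, so the pairs do not show which of these accounts for the step.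

Open, going by these compounds, is how phenylsulfanyl or 2,4-dichlorophenoxy would behave on either core, which would separate the sulfur from the chlorines. Also open, on these data alone, is the effect of an amine at the same aromatic carbon.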